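The source may report more compounds than this note shows. Statements on the series, on what has been measured and on what is new or still open speak of the compounds shown alone.

Working notes on the series. Three compounds have numbers in an assay on isolated protein for inhibition of protein tyrosine phosphatase type IVA 3 (Homo sapiens), tested at 5 ug/mL; a lower number here means less inhibition, a higher number more inhibition at the concentration tested (going by the name of the read-out). Compound 1, `O=C1NC(=S)S/C1=C\c1cc(Br)ccc1OCc1ccccc1Br`, gives 65.2%; compound 2, `O=C1NC(=S)S/C1=C\C=C\c1ccccc1OCc1ccccc1Br`, gives 63.1%; compound 3, `O=C1NC(=S)S/C1=C\C=C\c1ccccc1OCc1ccncc1`, gives 39.4%. Compound 3 stands lowest of the three numbers, with compound 2 the nearest and compound 1 the furthest, both beyond the scatter. For the measured compounds named here, the one measured step in a single place is a number 23.7 percentage points lower from compound 2 to compound 3 (beyond the scatter), a modest fall beyond the scatter.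

Compound 4, `COc1ccccc1/C=C/C=C1\SC(=S)NC1=O`, awaits this assay. It differs from compound 3 as follows: hydrogen in place of pyridin-4-yl on a saturated chain carbon bound to an oxygen on an aromatic ring. Going by the values given here, no measured step removes the group on the saturated chain carbon bound to an oxygen on an aromatic ring outright; the only step nearby, a number 23.7 percentage points lower from compound 2 to compound 3 (beyond the scatter), swaps one six-membered aromatic ring for another at that place and falls modestly. As far as these compounds go, that step does not settle the direction of removing the ring altogether, so a step of modest size in either direction, or none beyond the scatter, remains open. The reading expected for compound 4 is 30%, within 10% to 52%, which means an estimated step of a number 9.4 percentage points lower from compound 3 to compound 4 (within the scatter).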

Compound 4, a percentage reported as inhibition, at one concentration (the size of the read-out at that concentration, not a potency): 41.7%
Compound 4: middle estimate off by 11.7 percentage points, on the low side; the measured number falls inside the stated range.
By their numbers in this assay, from the lowest: compounds 3 and 4 (each within the scatter of the next); then compounds 2 and 1 (each within the scatter of the next).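

In this assay, replacing pyridin-4-yl with hydrogen on the saturated chain carbon bound to an oxygen on an aromatic ring, which turns (pyridin-4-yl)methoxy into methoxy, gives a number 2.3 percentage points higher from compound 3 to compound 4 (within the scatter), so the number is level with and without that ring. The same replacement of 2-bromophenyl gives a number 21.4 percentage points lower from compound 2 to compound 4 (beyond the scatter), which shows that of the three groups compared here, 2-bromophenyl alone stands apart, and the earlier fall a number 23.7 percentage points lower from compound 2 to compound 3 (beyond the scatter) reads as the absence of what 2-bromophenyl adds, not as a penalty for pyridin-4-yl. Nothing available accounts for this difference between the two rings.

The compounds shown do not separate the contribution of the bromine from that of the phenyl ring, a question that plain phenyl or 2-chlorophenyl at this place would address. As far as these compounds go, it also remains open whether the pattern holds for other groups on this carbon, such as a longer alkyl chain, a pyridin-2-yl ring or a carboxylic acid, and whether it carries over to the shared core of compound 1.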